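Coumarin series, monoamine oxidase A inhibition at one concentration

The source may report more compounds than this note shows. Statements on the series, on what has been measured and on what is new or still open speak of the compounds shown alone.

Measured compounds:
compound 1, `CCOc1cc(=O)oc2cc(OCc3cccc(Br)c3)ccc12`: 2.5%
compound 2, `O=C(O)COc1cc(=O)oc2cc(OCc3cccc(Cl)c3)ccc12`: 0%

Both numbers come from an assay on isolated protein (strain Sprague-Dawley) for inhibition of Amine oxidase [flavin-containing] A (Rattus norvegicus), read by spectrophotometry, with a stated time of 5 min, tested at 10 uM; on this read-out lower numbers stand for less inhibition and higher numbers for more inhibition at the one concentration tested (going by the name of the read-out). Compound 1 gives 2.5% and compound 2 gives 0%; compound 2 holds the lower of the two numbers, but the gap to compound 1 lies within the scatter, so no order between the two can be claimed. Neither compound shows inhibition that stands out from the scatter at this concentration.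

Compound 3, `CCNC(=O)Nc1cc(=O)oc2cc(OCc3cccc(Cl)c3)ccc12`, has not yet been measured in this assay. It differs from compound 2 in one place: (ethylcarbamoyl)amino in place of carboxymethoxy on an aromatic carbon. The group on the other side of the shared core, the halobenzyl ether, is the same in compound 2 and compound 3.

No step between two measured compounds is available, so nothing shown here links a change at this position to a change in the read-out. Among the compounds with values here, the only guide is that compound 1 and compound 2, which differ at this same position and elsewhere, both sit near zero. The step from compound 2 to compound 3 is therefore expected to be a number 3 percentage points higher from compound 2 to compound 3 (within the scatter), none beyond the scatter in either direction. For compound 3 the estimate in this assay is 3%, with a range from 0% to 20%.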

Compound 3, a percentage reported as inhibition, at one concentration (the size of the read-out at that concentration, not a potency): 0%
Estimate against measurement, compound 3: 3 percentage points above; the range from low to high includes it.
By their numbers in this assay, from the lowest: compounds 2, 3 and 1 (each within the scatter of the next).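

Within the data shown here, the first comparison that changes only one place shows no change at the digits printed from compound 2 to compound 3 (within the scatter) in this assay when (ethylcarbamoyl)amino stands in place of carboxymethoxy on this aromatic carbon, with the halobenzyl ether held the same. This swap replaces an oxygen-linked acid side chain with a nitrogen-linked urea side chain of 6 heavy atoms, and neither group lifts the read-out clear of the scatter around zero at the one concentration tested. Among these compounds, with both compounds this close to zero, the step shows only that this change does not bring out inhibition on this core, and it cannot rank the two groups. No measured evidence bears on why the read-out stays flat at this position.

Still open, on these data alone, is whether any other group on this aromatic carbon, such as a free amine, a carboxylic acid attached directly to the ring or a longer alkyl chain, would give a reading beyond the scatter in this assay. Also open is whether the halobenzyl ether itself limits the read-out, since every compound shown carries a halobenzyl ether and no compound with a plain benzyl ether, a methoxy group or a free hydroxyl group in its place is among them.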